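Cyano to Acetyl on the Shared Core in Guinea-Pig Cortex

A few compounds are considered here, and "the series" means these few. Any claim that something is new, unique, unknown or untested is made for them only; others in the source may bear on it.

Three compounds on one core were measured in an assay on Cerebral cortex for binding affinity to adenosine receptor A1 (Cavia porcellus), read by radioligand binding; on this read-out lower numbers stand for stronger inhibition and higher numbers for weaker inhibition. Compound 1 `CCCn1c(=O)n(CCC#N)c(=O)c2[nH]cnc21` gives 15900 nM. Compound 2 `CCCn1c(=O)n(CCC(C)=O)c(=O)c2[nH]cnc21` gives 11200 nM. Compound 3 `CCCn1c(=O)n(C)c(=O)c2c1ncn2CC#N` gives 6600 nM, the lowest of the three numbers, though its gap to compound 2 is within the scatter and only its gap to compound 1 lies beyond it.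

Compound 4 `CCCn1c(=O)n(C)c(=O)c2c1ncn2CC(C)=O` has not yet been measured. It differs from compound 3 by acetyl in place of cyano on a saturated chain carbon bound to an aromatic nitrogen. For the measured compounds named here, the one measured step that bears on this swap is the one a 1.4-fold lower number from compound 1 to compound 2 (0.15 log units; within the scatter), where the same exchange of cyano for acetyl sits on a chain carbon placed two bonds along the chain from an aromatic nitrogen rather than bound to it. That step stayed within the scatter, so an exchange at the directly bound carbon is expected to give at most a small shift in this assay, and if anything toward a lower number.

Compound 4 is therefore expected to come out near 5000 nM, within a range from 2500 nM to 11000 nM. The step of a 1.3-fold lower number from compound 3 to compound 4 (0.12 log units; within the scatter) is the estimated change, and it would remain within the scatter.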

Compound 4, inhibition constant: 95700 nM
Compound 4: middle estimate off by 19-fold (1.28 log units), on the low side; the measured number lies above the stated range.
By their numbers in this assay, from the lowest: compounds 3, 2 and 1 (each within the scatter of the next, the first and the last beyond it); then compound 4.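

In this assay, acetyl in place of cyano on a saturated chain carbon bound to an aromatic nitrogen turns out to be a large change, with a 15-fold higher number from compound 3 to compound 4 (1.16 log units; beyond the scatter). The earlier pair gave no sign of this, since the same exchange two bonds along the chain from an aromatic nitrogen gave only a 1.4-fold lower number from compound 1 to compound 2 (0.15 log units; within the scatter), which stays within the scatter. The exchange therefore has no single size in this assay, and its outcome depends on the core that carries it: the same change on two cores in this assay, a 1.4-fold lower number (0.15 log units; within the scatter) from compound 1 to compound 2 and a 15-fold higher number (1.16 log units; beyond the scatter) from compound 3 to compound 4, 21-fold (1.31 log units) apart, beyond the scatter of two such steps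

Compound 1 and compound 3 differ in more than one place, so the compounds shown cannot tell which of those differences separates the two steps, whether the placement of the chain on the core or the groups elsewhere on it. They also leave open whether an amine, a carboxylic acid or a longer chain on a saturated chain carbon bound to an aromatic nitrogen would give a number near that of compound 3 or near that of compound 4.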